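The source may hold more compounds than are shown below. What is called first, only, known or untested is meant among the compounds shown, and "the series" means these compounds.

In a toxicity assay on THP-1 cells (Homo sapiens) for inhibition (a higher number here means that more compound is tolerated, a lower number that less compound is tolerated), compound 1 `CCCC(=O)Nc1ncc(-c2ccc(OC)cc2)n1C` with propyl on the carbonyl carbon gives > 100000 nM as a limit and not a number. Compound 2 `COc1ccc(-c2cnc(NC(=O)c3ccc(Br)cc3)n2C)cc1` with 4-bromophenyl there gives > 100000 nM as a limit too. Compound 3 `COc1ccc(-c2cnc(NC(=O)c3ccco3)n2C)cc1` with furan-2-yl there gives > 100000 nM as a limit again, so it has no number of its own.

Compound 4 `COc1ccc(-c2cnc(NC(=O)c3cnco3)n2C)cc1` is still unmeasured. Its difference from compound 3 is 1,3-oxazol-5-yl in place of furan-2-yl on a carbonyl carbon and reads in words as 1,3-oxazol-5-yl in place of furan-2-yl on a carbonyl carbon. Bearing on this change are a step that the two limits leave unreadable from compound 1 to compound 3 and a step that the two limits leave unreadable from compound 2 to compound 3 and also a step that the two limits leave unreadable from compound 1 to compound 2 at the same place. Among the compounds with values here, none of the three has a readable size because of the limit of > 100000 nM in this assay, at which 3 of the 3 values shown sit, and so they set no scale for a step.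

Within the data shown here, since compound 3 sits at the limit of > 100000 nM in this assay, at which 3 of the 3 values shown sit, with no compound going against it, no step beyond the scatter is expected in this assay and no direction can be given. The expected change is a number no higher from compound 3 to compound 4 (the limit leaves the size open) as an estimate, and a further limit is the likeliest report. Compound 4 is expected at 100000 nM with an estimated range from 50000 nM to 200000 nM in this read-out.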

Compound 4, half-maximal cytotoxic concentration: > 100000 nM
Compound 4: only a limit was reported; the forecaster's own chance of this, stated with the estimate: 85%; the middle value lies on the limit itself.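

No step from compound 1, compound 2 or compound 3 to compound 4 can be read in this assay, because all four compounds stand at one limit: the limit of > 100000 nM in this assay, at which 4 of the 4 values shown sit.

The compounds shown leave open whether any group on the carbonyl carbon of the shared core gives a measurable cytotoxic concentration, and how far apart these four compounds truly lie.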